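The compounds below may be only part of what the source reports. "The series", "measured", "known", "first", "only" and "open" are said of these compounds alone.

Measured so far:
compound 1 `CC1=C(C)C(=O)C(c2cn([C@H]3C[C@H](O)[C@@H](CO)O3)c(=O)[nH]c2=O)=CC1=O` — 112000 nM
compound 2 `N#Cc1cn([C@H]2C[C@H](O)[C@@H](CO)O2)c(=O)[nH]c1=O` — > 200000 nM
compound 3 `CC(O)Cn1cnc2c(F)nc(N)nc21` — > 200000 nM

In an ADME assay on L1210/0 cells (Mus musculus) for cytotoxicity, with a stated time of 48 h (a higher number here means a weaker inhibitor, a lower number a stronger inhibitor), compound 1 gives 112000 nM. For compound 2 only a limit is recorded, > 200000 nM. Compound 3 likewise shows only a limit, > 200000 nM. Going by the values given here, two of the three values thus sit at the limit (the limit of > 200000 nM in this assay, at which 2 of the 3 values shown sit), and no step between measured compounds can be drawn from this set.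

Compound 4 `CCC#Cc1cn([C@H]2C[C@H](O)[C@@H](CO)O2)c(=O)[nH]c1=O` is not yet measured. It differs from compound 2 in that (but-1-yn-1-yl in place of cyano on an aromatic carbon). Since compound 2 shows only a limit, > 200000 nM, the size of any step in this assay is open; a move toward stronger inhibition, beyond the scatter, is expected. Compound 4 is expected to give about 50000 nM, within 5000 nM to 200000 nM. That estimate means an expected step of an at least 4.0-fold lower number from compound 2 to compound 4 (0.60 log units; beyond the scatter).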

Compound 4, half-maximal inhibitory concentration: > 200000 nM
Compound 4: no number, only a limit (the forecaster's own chance of this, stated with the estimate: 35%); middle value at least 4.0-fold (0.60 log units) from the limit.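

Going by these compounds alone, compound 2 and compound 4 are both recorded only as limits, so no step between them can be read: the limit of > 200000 nM in this assay, at which 3 of the 4 values shown sit.
The compounds shown leave open whether but-1-yn-1-yl in place of cyano on an aromatic carbon changes inhibition at all.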